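Ester change from compound 3 to compound 4

The source may hold more compounds than are shown below. What is called first, only, known or untested is meant among the compounds shown, and "the series" means these compounds.

Of the compounds shown here, three have been measured in an assay on isolated protein for inhibition of protein kinase C zeta type (Homo sapiens), with stated times of 1 h and 2.5 min, tested at 30 uM; on this read-out higher numbers stand for more inhibition at the one concentration tested (going by the name of the read-out) and lower numbers for less inhibition. Compound 1 `CCOC(=O)c1cscc1-c1ccc(OC)c(OC)c1` gives 3%. Compound 2 `CCOC(=O)c1c(-c2ccc(OC)c(OC)c2)csc1NC(N)=O` gives 14%. Among the compounds with values here, the only single-place step measured so far is a number 11 percentage points higher from compound 1 to compound 2 (beyond the scatter), a ureido in place of hydrogen on an aromatic carbon. Within the data shown here, compound 3 `COCC(C)OC(=O)c1c(-c2ccc(OC)c(OC)c2)csc1N` gives 49%, the highest of the three numbers, beyond the scatter above both compound 2 and compound 1; compound 3 differs from compound 2 in more than one place, so no step is computed for that pair.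

Compound 4 `COc1ccc(-c2csc(N)c2C(=O)OCc2ccc(F)cc2)cc1OC` is compound 3 with 4-fluorobenzyl in place of 1-(methoxymethyl)ethyl on an oxygen next to a carbonyl group. Among the measured compounds shown here, no measured step touches the group on the oxygen next to the carbonyl group, so the step from compound 1 to compound 2 gives no guide here. With nothing to go on, the expected outcome is a step of a number 4 percentage points lower from compound 3 to compound 4 (within the scatter) in this assay, with no direction favoured beyond the scatter. Compound 4 is therefore estimated at 45%, with a range from 20% to 70%.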

Compound 4, a percentage reported as inhibition, at one concentration (the size of the read-out at that concentration, not a potency): 2%
Estimate against measurement, compound 4: 43 percentage points above; the whole stated range lies above it.
By their numbers in this assay, from the lowest: compounds 4 and 1 (each within the scatter of the next); then compound 2; then compound 3.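

In this assay, within the data shown here, the group on the oxygen next to a carbonyl group proves far from neutral: 4-fluorobenzyl in place of 1-(methoxymethyl)ethyl gives a number 47 percentage points lower from compound 3 to compound 4 (beyond the scatter), the largest single-place step so far. This one change separates compound 3 at 49% from compound 4 at 2%, with the rest of the structure unchanged. No measurement shown here bears on why the step is this large.

The change brings in an aromatic ring and a fluorine and removes an ether oxygen all at once, so the compounds shown do not say which of these parts goes with the step. Open too, going by these compounds, is where a plain benzyl, a longer alkyl chain or a free carboxylic acid in place of the ester would fall relative to compound 3 and compound 4.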